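The source may report more compounds than this note shows. Statements on the series, on what has been measured and on what is new or still open speak of the compounds shown alone.

The compounds here share one core and differ only in the group at the far end of the chain. Compound 1 `Cc1ccccc1OCCCCCn1ccc(=O)[nH]c1=O` carries a methyl group on the aromatic ring. In an ADME assay on HEL cells (Homo sapiens) for cytotoxicity (on this read-out higher numbers stand for lower toxicity in this test and lower numbers for higher toxicity in this test), compound 1 gives > 100000 nM, which is a limit of the test rather than a number. Compound 2 `O=c1ccn(CCCCCOc2ccc([N+](=O)[O-])cc2)c(=O)[nH]1` carries a nitro group; in this assay compound 2 gives "not determined" (no result reported). Among the compounds with values here, compound 3 `CC(C)(C)c1ccc(OCCCCCn2ccc(=O)[nH]c2=O)cc1` carries a tert-butyl group, and in this assay compound 3 gives 40000 nM, the only plain number in this set. Compound 4 `CCCOC(=O)c1ccc(OCCCCCn2ccc(=O)[nH]c2=O)cc1` differs from compound 3 by propoxycarbonyl in place of tert-butyl on an aromatic carbon. Within the data shown here, no measured pair with a comparable change exists here. A modest step toward lower toxicity is expected, a 1.8-fold higher number from compound 3 to compound 4 (0.24 log units; within the scatter), so compound 4 is estimated at 70000 nM, between 25000 nM and 200000 nM.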

Compound 4, half-maximal cytotoxic concentration: > 100000 nM
Compound 4 was reported as a limit; the forecaster's own chance of this, stated with the estimate: 35%; middle value at least 1.4-fold (0.15 log units) away from the limit.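

In this assay, within the data shown here, this is the first step in the set that can be read, and it shows that the group on this aromatic carbon can change the read-out: propoxycarbonyl in place of tert-butyl gives an at least 2.5-fold higher number from compound 3 to compound 4 (0.39 log units; beyond the scatter). As far as these compounds go, the direction is toward lower toxicity in this test, but the full size of the step stays unknown. Compound 4 is recorded only as a limit: the limit of > 100000 nM in this assay, at which 2 of the 4 values shown sit.

Still open, from the compounds shown here alone, is how a carboxylic acid or an amine would read at this same place. A methoxycarbonyl group would show whether the propyl chain of the propoxycarbonyl group matters.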